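Compound 3: trifluoromethoxy in place of chloro

This account rests on a few compounds, and the source may have more. Where it says the series, first, only, none or still open, it means among the compounds named here.

Working notes on the series. Compound 1 `Cc1c(Cc2ccccc2S(=O)(=O)c2ccc(F)cc2)c2c(n1CC(=O)O)CCNC2=O` and compound 2 `Cc1c(Cc2ccccc2S(=O)(=O)c2ccc(Cl)cc2)c2c(n1CC(=O)O)CCNC2=O` share one core and differ only at a single aromatic carbon. In a functional assay on CHO.K1 cells for antagonist activity at prostaglandin D2 receptor 2 (Homo sapiens), read by GTPgammaS binding, with a stated time of 1 h (a higher number here means a weaker inhibitor, a lower number a stronger inhibitor), compound 1 gives 3.3 nM, and compound 2 gives 8.5 nM. Among the measured compounds shown here, compound 2 stands highest of the two measured numbers; the only measured step, a 2.6-fold higher number from compound 1 to compound 2 (0.41 log units; beyond the scatter), runs toward the weaker side. Compound 3 `Cc1c(Cc2ccccc2S(=O)(=O)c2ccc(OC(F)(F)F)cc2)c2c(n1CC(=O)O)CCNC2=O` carries trifluoromethoxy in place of chloro on an aromatic carbon. For the measured compounds named here, no measured step covers this exchange directly; the fluoro-to-chloro step is the sole guide, and it shows that enlarging the group at this carbon raised the number. The group entering here is larger again, so a further rise in this assay beyond the scatter is expected, with the size uncertain. Compound 3 is estimated at 18 nM in this assay, within a range of 6 nM to 55 nM. The expected step is a 2.1-fold higher number from compound 2 to compound 3 (0.33 log units; beyond the scatter).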

Compound 3, half-maximal inhibitory concentration: 6.6 nM
Compound 3: the middle estimate sits 2.7-fold (0.44 log units) above what was measured, and the stated range covers the measured number.
By their numbers in this assay, from the lowest: compounds 1, 3 and 2 (each within the scatter of the next, the first and the last beyond it).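

In this assay, trifluoromethoxy, with 5 heavy atoms against the single chlorine atom, is accommodated at this aromatic carbon without a step beyond the scatter: the exchange gives a 1.3-fold lower number from compound 2 to compound 3 (0.11 log units; within the scatter), and against fluoro it gives a 2.0-fold higher number from compound 1 to compound 3 (0.30 log units; within the scatter). Compound 3 thus cannot be separated from either compound 1 or compound 2, although those two are separated by a 2.6-fold higher number from compound 1 to compound 2 (0.41 log units; beyond the scatter), so the heavy-atom count of the group does not order the three compounds, and compound 3 goes against any such trend. Nothing available bears on what lies behind this result.

On these data alone, how a nitrile, a methoxy or an amine would read at this carbon remains open. Also open, as far as these compounds go, is whether a bare hydrogen here, or a methyl at another carbon of this ring, would hold the number in the same range.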